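Compound 3: Dimethoxyphenyl in Place of Fluorophenyl

The source may report more compounds than this note shows. Statements on the series, on what has been measured and on what is new or still open speak of the compounds shown alone.

Compound 2 `N#CC1=C(N)Oc2c(N)cc3nc4ccccc4nc3c2C12C(=O)N(Cc1cnnn1-c1ccc(F)cc1)c1ccccc12` was tested in a functional assay on HepG2 cells (Homo sapiens) for antiproliferative activity, read by MTT assay, with a stated time of 48 h (a higher number here means a weaker inhibitor, a lower number a stronger inhibitor), where compound 2 gives > 50000 nM, a limit of the assay rather than a number. Compound 1 `CCOc1ccccc1-n1nncc1CN1C(=O)C2(C(C#N)=C(N)Oc3c2c2nc4ccccc4nc2c2ccccc32)c2ccccc21` gives > 50000 nM in this assay, again a limit. Compound 2 thus stands at the limit of > 50000 nM in this assay, at which 2 of the 2 values shown sit. Compound 3 `COc1ccc(OC)c(-n2nncc2CN2C(=O)C3(C(C#N)=C(N)Oc4c(N)cc5nc6ccccc6nc5c43)c3ccccc32)c1` differs from compound 2 by 2,5-dimethoxyphenyl in place of 4-fluorophenyl on an aromatic nitrogen. Within the data shown here, no measured step between these compounds exists, and both known values sit at a limit. In this assay no step beyond the scatter is expected. Compound 3 is expected to give about 50000 nM, between 15000 nM and 200000 nM, probably again as a limit. The expected step is a number no higher from compound 2 to compound 3 (the limit leaves the size open).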

Compound 3, half-maximal inhibitory concentration: 45100 nM
Compound 3: middle estimate off by 1.1-fold (0.04 log units), on the high side; the measured number falls inside the stated range.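

Replacing 4-fluorophenyl with 2,5-dimethoxyphenyl on this aromatic nitrogen gives, in this assay, an at least 1.1-fold lower number from compound 2 to compound 3 (0.04 log units; that floor lies within the scatter). Among these compounds, compound 3 thus gives the only actual number in this set, but it shows no clear gain at this position, and the true size of the step remains unknown. The other values are limits, so most of the set marks only the edge of the assay: the limit of > 50000 nM in this assay, at which 2 of the 3 values shown sit.

As far as these compounds go, whether an amine or a carboxylic acid on this phenyl ring would shift the number beyond the scatter remains open.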